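Swapping methoxy for chloro on the aryl ring

This account rests on a few compounds, and the source may have more. Where it says the series, first, only, none or still open, it means among the compounds named here.

Measured compounds:
- compound 1 `COc1ccc(-c2nc(SC)n(C)c(=O)c2C#N)cc1`: 58 ug/mL
- compound 2 `COc1ccc(-c2nc(NN)n(C)c(=O)c2C#N)cc1`: 41 ug/mL
- compound 3 `CCOC(=O)c1cnn(-c2nc(-c3ccccc3Cl)c(C#N)c(=O)n2C)c1N`: 78 ug/mL

In a functional assay, with a stated time of 20 min (a higher number here means a weaker inhibitor, a lower number a stronger inhibitor), compound 2 gives 41 ug/mL. Its nearest neighbour is compound 1, and the step of a 1.4-fold lower number from compound 1 to compound 2 (0.15 log units; within the scatter) shows that the two stand within the ordinary scatter of each other. Among the compounds with values here, compound 3 gives 78 ug/mL, a number that also lies within the scatter of compound 2, so no measured compound separates itself from compound 2.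

Compound 4 `Cn1c(NN)nc(-c2ccc(Cl)cc2)c(C#N)c1=O` has not yet been measured. It differs from compound 2 by chloro in place of methoxy on an aromatic carbon. Within the data shown here, none of the measured steps touches this position: the only single-point step, from compound 1 to compound 2, changes a different group, and compound 3 differs from the others in several places at once, so its value says little about the methoxy-to-chloro swap alone. Among the measured compounds shown here, with no step to lean on, compound 4 is expected to stay close to compound 2, giving a step of a 1.1-fold higher number from compound 2 to compound 4 (0.04 log units; within the scatter) in this assay. For compound 4 the estimate is 45 ug/mL, expected to fall between 20 ug/mL and 100 ug/mL.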

Compound 4, half-maximal inhibitory concentration: 44 ug/mL
For compound 4 the middle estimate is 1.0-fold (0.01 log units) above the measured one; low and high end bracket the measured number.
By their numbers in this assay, from the lowest: compounds 2, 4, 1 and 3 (each within the scatter of the next).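

The earlier compounds shown here offered no comparison in a single place at this position on the aromatic ring, and in this assay the swap of methoxy for chloro now provides one, with a 1.1-fold higher number from compound 2 to compound 4 (0.03 log units; within the scatter). For this pair, then, methoxy, which carries a hydrogen-bond acceptor, can give way to chloro, which carries none, without a change that stands out from the scatter. Nothing available explains why this exchange leaves the number within the scatter.

From the compounds shown here alone, whether an amine, a carboxylic acid or a longer chain such as butoxy in this place would move the number beyond the scatter remains open. Going by these compounds, it is also open whether the same swap would behave alike on the core of compound 1, which carries methylsulfanyl.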